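Trifluoromethyl in Place of Fluoro: Expected Cytotoxicity

The source may hold more compounds than are shown below. What is called first, only, known or untested is meant among the compounds shown, and "the series" means these compounds.

Compound 1 `CCCCCCc1cn(C(c2ccccc2)c2cc3cc(Br)ccc3nc2OC)nn1` gives 2.32% in an ADME assay on PC-3 cells (Homo sapiens) for cytotoxicity, read by sulforhodamine B assay, with a stated time of 48 h, tested at 10 uM; on this read-out higher numbers stand for more inhibition at the one concentration tested (going by the name of the read-out) and lower numbers for less inhibition. Compound 2 `COc1nc2ccc(Br)cc2cc1C(c1ccccc1)n1cc(-c2ccccc2F)nn1` gives 13.4% in this assay, the higher of the two numbers, and the step of a number 11.1 percentage points higher from compound 1 to compound 2 (beyond the scatter) is modest. Compound 3 `COc1nc2ccc(Br)cc2cc1C(c1ccccc1)n1cc(-c2ccccc2C(F)(F)F)nn1` differs from compound 2 by trifluoromethyl in place of fluoro on an aromatic carbon. Within the data shown here, the single measured step exchanges hexyl for 2-fluorophenyl and does not bear on a change from fluoro to trifluoromethyl, so no measured step speaks to it. The step to compound 3 is therefore expected to stay within the scatter, estimated as a number 1.6 percentage points higher from compound 2 to compound 3 (within the scatter). Compound 3 is expected to give about 15%, between 0% and 35%.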

Compound 3, a percentage reported as inhibition, at one concentration (the size of the read-out at that concentration, not a potency): 17.4%
Compound 3: the middle estimate sits 2.4 percentage points below what was measured, and the stated range covers the measured number.
By their numbers in this assay, from the lowest: compound 1; then compounds 2 and 3 (each within the scatter of the next).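

In this assay, the aromatic carbon ortho to a large group takes trifluoromethyl in place of fluoro with little effect on the read-out, with a number 4 percentage points higher from compound 2 to compound 3 (within the scatter) for this exchange. The 2-(trifluoromethyl)phenyl group still stands apart from hexyl, with a number 15.1 percentage points higher from compound 1 to compound 3 (beyond the scatter) as the step, so a second aryl group on the triazole-bearing carbon also lies beyond the scatter from hexyl. Nothing available explains this result. Going by these compounds, whether an amine or a carboxylic acid on this aromatic carbon would give a different number stays open.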